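Amino acid ester series: isobutyl in place of isopropyl

A few compounds are considered here, and "the series" means these few. Any claim that something is new, unique, unknown or untested is made for them only; others in the source may bear on it.

- compound 1 `CC(C)C[C@@H](N)C(=O)OC[C@H]1O[C@@H](n2cnc3c(N)ncnc32)[C@@H](O)[C@@H]1O`: 0.04 h
- compound 2 `CC(C)[C@H](N)C(=O)OC[C@H]1O[C@@H](n2cnc3c(N)ncnc32)[C@@H](O)[C@@H]1O`: 0.3 h

Both values come from an ADME assay on intestine (Rattus norvegicus) for metabolic stability; on this read-out lower numbers stand for a shorter-lived compound and higher numbers for a longer-lived compound. Within the data shown here, of the two compounds measured so far, compound 2 stands highest at 0.3 h, and the gap to compound 1 lies beyond the scatter.

The next compound to be measured is compound 3 `CC(C)C[C@H](N)C(=O)OC[C@H]1O[C@@H](n2cnc3c(N)ncnc32)[C@@H](O)[C@@H]1O`. Relative to compound 2, the change is isobutyl in place of isopropyl on a saturated chain carbon bound to an amine nitrogen and a carbonyl carbon. In words, isobutyl stands in place of isopropyl on a saturated chain carbon bound to an amine nitrogen and a carbonyl carbon. Cut one bond further out, this reads 1-amino-3-methylbutyl in place of 1-amino-2-methylpropyl.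

Among the measured compounds shown here, only one measured step bears on this change: a 7.5-fold higher number from compound 1 to compound 2 (0.88 log units; beyond the scatter). That step swaps the same two groups in the opposite direction, and it is a single observation, so no pattern can be claimed from it. A step of similar size towards a lower number is therefore expected in this assay, namely a 5.0-fold lower number from compound 2 to compound 3 (0.70 log units; beyond the scatter). The estimated value for compound 3 is 0.06 h, with an expected range from 0.02 h to 0.2 h.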

Compound 3, half-life: 0.03 h
Compound 3: middle estimate off by 2.0-fold (0.30 log units), on the high side, and the stated range covers the measured number.
By their numbers in this assay, from the lowest: compounds 3 and 1 (each within the scatter of the next); then compound 2.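

In this assay, isobutyl in place of isopropyl on a saturated chain carbon bound to an amine nitrogen and a carbonyl carbon gives a 10-fold lower number from compound 2 to compound 3 (1.00 log units; beyond the scatter), so the drop on moving to isobutyl no longer rests on a single observation. The configuration as drawn at that carbon does not separate the two isobutyl compounds, with a 1.3-fold lower number from compound 1 to compound 3 (0.12 log units; within the scatter), and this comparison isolates one variable: the fact that compounds 1 and 3 differ only in the configuration as drawn. Among these three compounds, the read-out follows the group rather than the drawn configuration, with the two isobutyl compounds together at the short-lived end and the isopropyl compound 2 alone at the longer-lived end.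

Going by these compounds, the effect of configuration has been read only for isobutyl, so whether isopropyl with the opposite configuration as drawn would keep the number of compound 2 stays open. Also open, on these data alone, is where a methyl group, an unbranched butyl chain or a chain ending in a carboxylic acid would fall in this assay, and so whether the higher number belongs to isopropyl alone or to shorter groups in general.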